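A few compounds are considered here, and "the series" means these few. Any claim that something is new, unique, unknown or untested is made for them only; others in the source may bear on it.

Measured so far:
compound 1 `COc1cccc(/C=C/C(=O)Nc2cc(C(=O)c3cc(OC)c(OC)c(OC)c3)cc(OC)c2OC)c1` — 12500 nM
compound 2 `COc1ccc(/C=C/C(=O)Nc2cc(C(=O)c3cc(OC)c(OC)c(OC)c3)cc(OC)c2OC)cc1N` — 12700 nM

Among the measured compounds shown here, in a functional assay on DU-145 cells (Homo sapiens) for cytotoxicity, read by MTT assay, with a stated time of 72 h (a higher number here means a weaker inhibitor, a lower number a stronger inhibitor), compound 2 gives 12700 nM, the higher of the two numbers at hand; its only neighbour is compound 1 with 12500 nM, and the step of a 1.0-fold higher number from compound 1 to compound 2 (0.01 log units; within the scatter) lies within the scatter, so the two cannot be ranked. The next compound is compound 3 `COc1cc(C(=O)c2cc(OC)c(OC)c(OC)c2)cc(NC(=O)/C=C/c2ccc(C(F)(F)F)cc2)c1OC`, which differs from compound 2 by 4-(trifluoromethyl)phenyl in place of 3-amino-4-methoxyphenyl on a double-bonded chain carbon bound to a double-bonded chain carbon. For the measured compounds named here, the single measured step at this position, a 1.0-fold higher number from compound 1 to compound 2 (0.01 log units; within the scatter), shows that exchanging one substituted phenyl for another there left the number unchanged. Going by the values given here, no measured step tests a ring that carries no donors or acceptors, so the present data give no ground to expect a move beyond the scatter in this assay. Compound 3 is therefore expected at about 12000 nM, with a range of 5000 nM to 30000 nM. The step of a 1.1-fold lower number from compound 2 to compound 3 (0.02 log units; within the scatter) is the expected outcome, essentially no change.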

Compound 3, half-maximal inhibitory concentration: 5100 nM
Estimate against measurement, compound 3: 2.4-fold (0.37 log units) above; the measured number falls inside the stated range.
By their numbers in this assay, from the lowest: compound 3; then compounds 1 and 2 (each within the scatter of the next).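

In this assay this position on a double-bonded chain carbon proves able to move the number, which the earlier pair did not show: 4-(trifluoromethyl)phenyl gives a 2.5-fold lower number from compound 2 to compound 3 (0.40 log units; beyond the scatter) and also a 2.5-fold lower number from compound 1 to compound 3 (0.39 log units; beyond the scatter) in the comparison with 3-methoxyphenyl. Both steps are modest, yet they agree, and they set compound 3 apart from compounds 1 and 2, which stay within the scatter of each other. Nothing at hand accounts for the difference between these rings.

The compounds shown leave open whether the change follows from the trifluoromethyl group itself or from the loss of the methoxy and amino groups. A plain phenyl, a 4-chlorophenyl or a 4-cyanophenyl at this position would separate those readings.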